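The source may hold more compounds than are shown below. What is called first, only, known or untested is meant among the compounds shown, and "the series" means these compounds.

Measured compounds in a functional assay on the whole organism (Ehrlich cells, Mus musculus) for antiproliferative activity, with a stated time of 24 h, at a dose of 0.2 mmol/kg by the intraperitoneal route; on this read-out lower numbers stand for less inhibition and higher numbers for more inhibition at the one dose given (going by the name of the read-out):
compound 1 `Nc1ccccc1NC(=O)CCCNCC(=O)Nc1ccc(Cl)cc1`: 75%
compound 2 `Nc1ccccc1NC(=O)CCCNCC(=O)Nc1cccc([N+](=O)[O-])c1`: 36%
compound 3 `Nc1ccccc1NC(=O)CCCNCC(=O)Nc1cc(Cl)ccc1Cl`: 50.9%

Compound 3 stands second highest of the three: a number 24.1 percentage points lower from compound 1 to compound 3 (beyond the scatter), while a number 14.9 percentage points higher from compound 2 to compound 3 (beyond the scatter). Compound 4 `COc1ccc(NC(=O)CNCCCC(=O)Nc2ccccc2N)cc1` differs from compound 3 in one place: 4-methoxyphenyl in place of 2,5-dichlorophenyl on an amide-type nitrogen. Among the compounds with values here, no measured step carries a methoxy group, so the expectation rests on the two steps into compound 3. Against 2,5-dichlorophenyl, the 4-chlorophenyl of compound 1 gave the highest number, and the 4-methoxyphenyl of compound 4 shares that naming; against 3-nitrophenyl, compound 3 was higher. A modest rise, or none beyond the scatter, is therefore expected: a number 7.1 percentage points higher from compound 3 to compound 4 (within the scatter). Compound 4 is estimated at 58%, with a range from 35% to 78%.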

Compound 4, a percentage reported as inhibition, in the whole organism at one dose (the size of the read-out at that dose, not a potency): 63.3%
Beside the measured number, compound 4's estimate is 5.3 percentage points below it; the range from low to high includes it.
By their numbers in this assay, from the lowest: compound 2; then compound 3; then compound 4; then compound 1.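

In this assay, a 4-methoxyphenyl on the amide-type nitrogen gives a number inside the earlier span, above 2,5-dichlorophenyl (a number 12.4 percentage points higher from compound 3 to compound 4 (beyond the scatter)) and 3-nitrophenyl (a number 27.3 percentage points higher from compound 2 to compound 4 (beyond the scatter)), so a group without chlorine need not fall as low as compound 2. Methoxy in place of chloro on an aromatic carbon still lowers the number (a number 11.7 percentage points lower from compound 1 to compound 4 (beyond the scatter)), and compound 1 stays highest of the four. No measurement at hand accounts for these differences.

As far as these compounds go, whether an amine or a carboxylic acid on that aromatic carbon would match compound 1 stays open. A single dose also leaves potency open.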